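This account rests on a few compounds, and the source may have more. Where it says the series, first, only, none or still open, it means among the compounds named here.

Measured compounds:
Compound 1, `CCNC(=O)/C=C/c1c(/C=C/c2ccc(OC)cc2)cc(OC)cc1OC`: 7860 nM in a functional assay on A549 cells (Homo sapiens) for inhibition, read by MTT assay, with a stated time of 48 h; on this read-out lower numbers stand for stronger inhibition and higher numbers for weaker inhibition
Compound 2, `COc1ccc(/C=C/c2cc(OC)cc(OC)c2/C=C/C(=O)N2CCCCC2C)cc1`: 5770 nM
Compound 3, `CCCCCCNC(=O)/C=C/c1c(/C=C/c2ccc(OC)cc2)cc(OC)cc1OC`: 6230 nM

Among these three, compound 1 carries the highest number, but its neighbours lie close to it: the step of a 1.4-fold lower number from compound 1 to compound 2 (0.13 log units; within the scatter) and the step of a 1.3-fold lower number from compound 1 to compound 3 (0.10 log units; within the scatter) both stay within the scatter, as does the step of a 1.1-fold higher number from compound 2 to compound 3 (0.03 log units; within the scatter). The three compounds share one core and differ only in the group attached to the carbonyl carbon of the amide-type part.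

Compound 4, `COc1ccc(/C=C/c2cc(OC)cc(OC)c2/C=C/C(=O)N2CCCC(C)C2)cc1`, has not yet been measured. It differs from compound 1 in a single place: 3-methylpiperidin-1-yl in place of ethylamino on a carbonyl carbon. The closest guide is the step from compound 1 to compound 2, where another six-membered non-aromatic ring with one hetero atom replaced the same ethylamino group on the same carbonyl carbon, and the number moved by a 1.4-fold lower number from compound 1 to compound 2 (0.13 log units; within the scatter). Because the step of a 1.4-fold lower number from compound 1 to compound 2 (0.13 log units; within the scatter) and the step of a 1.3-fold lower number from compound 1 to compound 3 (0.10 log units; within the scatter) both stay within the scatter, compound 4 is expected to show the step of a 1.2-fold lower number from compound 1 to compound 4 (0.10 log units; within the scatter), nothing beyond the scatter. Compound 4 is therefore estimated at 6300 nM, with a range from 3200 nM to 12500 nM.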

Compound 4, half-maximal inhibitory concentration: 5820 nM
Compound 4: the middle estimate sits 1.1-fold (0.03 log units) above what was measured, within the range that was stated.
By their numbers in this assay, from the lowest: compounds 2, 4, 3 and 1 (each within the scatter of the next).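

Read in this assay, the step of a 1.0-fold higher number from compound 2 to compound 4 (0.00 log units; within the scatter) stays within the scatter, so moving the methyl group from the 2-position to the 3-position of the piperidine ring makes no readable difference here. The steps of a 1.4-fold lower number from compound 1 to compound 4 (0.13 log units; within the scatter) and a 1.1-fold lower number from compound 3 to compound 4 (0.03 log units; within the scatter) also stay within the scatter, which means that this second ring group, with no hydrogen-bond donor, cannot be told apart from either ethylamino or hexylamino on the carbonyl carbon. Nothing available explains why these numbers lie so close together.

From the compounds shown here alone, it remains open whether a morpholin-4-yl or piperazin-1-yl ring, or a carboxylic acid at the end of the hexyl chain, would take the number beyond the scatter. Going by these compounds, all four compounds also keep the methoxy groups of the shared core, so the effect of replacing them with hydroxy groups remains unknown.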